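Extending the Chain on a Triazole Ester

The source may report more compounds than this note shows. Statements on the series, on what has been measured and on what is new or still open speak of the compounds shown alone.

Measured so far:
Compound 1, `CCCCCCCCc1cn(C/C=C(/C)CCC=C(C)C)nn1`: 6.92
Compound 2, `CCCCCCCCc1cn(C/C=C(/C)CC/C=C(\C)CCC=C(C)C)nn1`: 8.76
Compound 3, `COC(=O)c1cn(C/C=C(\C)CCC=C(C)C)nn1`: 3.2

Of the compounds shown here, three have been measured in a physicochemical assay for lipophilicity, measured as octanol-water partition; on this read-out higher numbers stand for higher lipophilicity and lower numbers for lower lipophilicity. Compound 1 carries a long saturated chain on its core, and in this assay compound 1 gives 6.92. Compound 2 differs from compound 1 by 3-methylbut-2-en-1-yl in place of hydrogen on a saturated chain carbon bound to a double-bonded chain carbon, and this change gave a number 1.84 log units higher from compound 1 to compound 2 (beyond the scatter).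

Compound 3 has a different core, and the difference between the core of compound 3 and the core of compound 1 is not broken down here. In this assay compound 3 gives 3.2, the lowest of the three numbers, with steps to both other compounds that lie beyond the usual scatter.

Compound 4, `COC(=O)c1cn(C/C=C(\C)CC/C=C(\C)CCC=C(C)C)nn1`, has not yet been measured. It differs from compound 3 by 3-methylbut-2-en-1-yl in place of hydrogen on a saturated chain carbon bound to a double-bonded chain carbon. This is the same change as the one from compound 1 to compound 2, at the same kind of place, and it occurs twice among the compounds shown. Because that earlier change produced a number 1.84 log units higher from compound 1 to compound 2 (beyond the scatter), a step of similar size is expected here. On that basis the step to compound 4 is expected to be a number 1.80 log units higher from compound 3 to compound 4 (beyond the scatter). Compound 4 is therefore estimated to give 5 in this assay. The expected range for compound 4 runs from 4.5 to 5.5, allowing that the change sits on a different core.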

Compound 4, partition coefficient: 5.25
Estimate against measurement, compound 4: 0.25 log units below; the range from low to high includes it.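

In this assay, putting 3-methylbut-2-en-1-yl in place of hydrogen on a saturated chain carbon bound to a double-bonded chain carbon gave a number 2.05 log units higher from compound 3 to compound 4 (beyond the scatter), while the same change on the other core gave a number 1.84 log units higher from compound 1 to compound 2 (beyond the scatter), so on both cores the number rose and each step is large. This shows that the change carried over from the core of compound 1 to the core of compound 3 with the same direction, which makes the earlier step a useful guide for this pair, but two cores are too few to establish a rule for other cores in the series. No measurement shown here explains why the change has this effect on either core.

The compounds shown leave open whether the step would keep its direction and size on a core bearing a carboxylic acid or an amine, since neither group appears among them. They also leave open whether a still longer chain, made by adding another 3-methylbut-2-en-1-yl at the same kind of place, would raise the number again by a similar amount.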